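The source may hold more compounds than are shown below. What is called first, only, known or untested is meant among the compounds shown, and "the series" means these compounds.

Compound 1 `COc1cc(/C=C/C(=O)OCCCO[N+](=O)[O-])ccc1OCCCO[N+](=O)[O-]` in a functional assay on SKBR cells (Homo sapiens) for cytotoxicity, read by resazurin assay, with a stated time of 72 h (on this read-out higher numbers stand for weaker inhibition and lower numbers for stronger inhibition), gives > 50000 nM, a limit of the assay rather than a number.
Compound 2 `O=C(/C=C/c1ccc(OCCCCCCO[N+](=O)[O-])c(O)c1)OCCCCCCO[N+](=O)[O-]` in this assay gives 39700 nM.
Compound 3 `COc1cc(/C=C/C(=O)OCCCCCCO[N+](=O)[O-])ccc1OCCCCCCO[N+](=O)[O-]` in this assay gives > 50000 nM, which is again a limit of the assay and not a number.

Compounds 3 and 2 differ in one place only: hydrogen in place of methyl on an oxygen on an aromatic ring. The step of an at least 1.2-fold lower number from compound 3 to compound 2 (0.10 log units; that floor lies within the scatter) is small, and since compound 3 sits at a limit, only a floor for the step is known; that floor lies within the usual scatter, so the two values cannot be put in order. Two of the three values shown sit at the same limit (the limit of > 50000 nM in this assay, at which 2 of the 3 values shown sit).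

Compound 4 `O=C(/C=C/c1ccc(OCCCO[N+](=O)[O-])c(O)c1)OCCCO[N+](=O)[O-]` has not yet been measured. It stands to compound 1 as compound 2 stands to compound 3: hydrogen in place of methyl on an oxygen on an aromatic ring. The surroundings of the place are described in the same words in both pairs, so this is the same change. How the core of compound 1 differs from the core of compound 3 is not broken down here.

Among the measured compounds shown here, compound 1 gives only a limit in this assay, and the one measured example of this change gave a step whose floor lies within the scatter. The step from compound 1 to compound 4 is therefore expected to be modest, an at least 1.1-fold lower number from compound 1 to compound 4 (0.04 log units; that floor lies within the scatter). Compound 4 is expected to give about 45000 nM in this assay. For compound 4 the expected range runs from 20000 nM to 100000 nM, with a real chance that the assay again reports only a limit.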

Compound 4, half-maximal inhibitory concentration: 4810 nM
Beside the measured number, compound 4's estimate is 9.4-fold (0.97 log units) above it, and the stated range ends above it.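

Going from methoxy to hydroxy on the core of compound 1 gives a large step in this assay, an at least 10-fold lower number from compound 1 to compound 4 (1.01 log units; beyond the scatter), so on this core the change clearly matters. On the core of compound 3 the same change can be read only as a floor that lies within the scatter, so the data do not show whether the two cores respond alike or differently: the same change on two cores in this assay, an at least 1.2-fold lower number (0.10 log units; that floor lies within the scatter) from compound 3 to compound 2 and an at least 10-fold lower number (1.01 log units; beyond the scatter) from compound 1 to compound 4; the limit leaves it open whether they differ With only two pairs, each starting from a limit, this shows that the change can bring a large step on one core, but neither that it will do so on another core nor how large the true step is on either: the limit of > 50000 nM in this assay, at which 2 of the 4 values shown sit.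

The compounds shown leave open what other groups would do on the same oxygen of the aromatic ring, such as an ethyl group, or an amine in place of the hydroxy. They also leave open how a carboxylic acid at the end of the chain, or a longer chain than those shown, would read in this assay.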